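Half-life limits and the step to compound 4

The source may report more compounds than this note shows. Statements on the series, on what has been measured and on what is new or still open speak of the compounds shown alone.

Measured in an ADME assay on microsomes from liver (Rattus norvegicus) for metabolic stability (on this read-out higher numbers stand for a longer-lived compound and lower numbers for a shorter-lived compound), each entry a limit and not a number:
compound 1 `Nc1nc(NCCNc2ncc(-c3ncc[nH]3)c(-c3ccc(F)cc3F)n2)ccc1[N+](=O)[O-]`: > 0.5 h
compound 2 `Nc1nc(NCCNc2ncc(-c3ncc[nH]3)c(-c3ccc(F)cc3Br)n2)ccc1[N+](=O)[O-]`: > 0.5 h
compound 3 `Nc1nc(NCCNc2ncc(-c3ncc[nH]3)c(-c3cc(F)c(Cl)cc3F)n2)ccc1[N+](=O)[O-]`: > 0.5 h

In this assay compound 3 gives > 0.5 h, which is a limit. The whole set stands the same way, with the limit of > 0.5 h in this assay, at which 3 of the 3 values shown sit. Compound 4 `COc1cc(Cl)ccc1-c1nc(NCCNc2ccc([N+](=O)[O-])c(N)n2)ncc1-c1ncc[nH]1`, still unmeasured, differs from compound 3 by one change: 4-chloro-2-methoxyphenyl in place of 4-chloro-2,5-difluorophenyl on an aromatic carbon. In words, this is 4-chloro-2-methoxyphenyl in place of 4-chloro-2,5-difluorophenyl on an aromatic carbon.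

The measured steps that bear on it are a step that the two limits leave unreadable from compound 1 to compound 2, a step that the two limits leave unreadable from compound 1 to compound 3 and a step that the two limits leave unreadable from compound 2 to compound 3. For the measured compounds named here, none of them has a readable size, and no measured compound carries the methoxy group. No direction can therefore be drawn, and no change beyond the scatter is expected. The expected result is a step that the limit leaves unreadable from compound 3 to compound 4. A further limit reading is also quite possible. For compound 4 the estimate is 0.6 h, with an expected range from 0.25 h to 1.5 h.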

Compound 4, half-life: > 0.5 h
Compound 4: only a limit was reported; the forecaster's own chance of this, stated with the estimate: 60%; the middle value does not contradict the limit.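

In this assay compound 4 gives > 0.5 h as a limit. For the compounds shown here, no step among compound 1, compound 2, compound 3 and compound 4 can be read, since all four sit at one limit: the limit of > 0.5 h in this assay, at which 4 of the 4 values shown sit. The compounds shown leave open the actual half-life of each compound and whether any of these aryl changes alters it.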